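A few compounds are considered here, and "the series" means these few. Any claim that something is new, unique, unknown or untested is made for them only; others in the source may bear on it.

Compound 3 `CN1Cc2ccc(OCCc3ccccc3)cc2[C@@H](O)C1` carries a benzyl group on a saturated chain carbon bound to an oxygen on an aromatic ring. In an ADME assay on Vero cells (Chlorocebus sabaeus) for cytotoxicity, read by sulforhodamine B assay, with a stated time of 72 h (on this read-out lower numbers stand for stronger inhibition and higher numbers for weaker inhibition), compound 3 reaches only a limit, > 50000 nM. Compound 4 `CN1Cc2ccc(OCCCc3ccccc3)cc2[C@@H](O)C1` differs from it by benzyl in place of phenyl on a saturated chain carbon, two bonds along the chain from an oxygen on an aromatic ring. The nearest comparisons are compound 1 `COc1ccc2c(c1)[C@@H](O)CN(C)C2` and compound 2 `Cc1ccccc1COc1ccc2c(c1)[C@@H](O)CN(C)C2`. In this assay compound 1 gives a limit, > 100000 nM. In this assay compound 2 likewise gives a limit, > 100000 nM. The steps a step that the two limits leave unreadable from compound 1 to compound 2, a step that the two limits leave unreadable from compound 1 to compound 3 and a step that the two limits leave unreadable from compound 2 to compound 3 carry no readable size because the limit of > 100000 nM in this assay, at which 2 of the 3 values shown sit, and the limit of > 50000 nM in this assay, at which 1 of the 3 values shown sits, cap every value. So no measured step speaks to this change, and no shift beyond the scatter is expected. Compound 4 is expected to give 100000 nM, somewhere from 30000 nM to 300000 nM. The expected step is a step that the limit leaves unreadable from compound 3 to compound 4.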

Compound 4, half-maximal inhibitory concentration: > 50000 nM
Compound 4: no number, only a limit (the forecaster's own chance of this, stated with the estimate: 80%); the middle value is on the limit's open side.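

Compound 3 and compound 4 both give only a limit in this assay, so the step between them has no readable size: the limit of > 50000 nM in this assay, at which 2 of the 4 values shown sit.

From the compounds shown here alone, whether benzyl in place of phenyl changes cytotoxicity at all remains open, as does the true value of each compound.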